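Swapping a hydroxyethyl for an isobutyl side chain

The source may report more compounds than this note shows. Statements on the series, on what has been measured and on what is new or still open speak of the compounds shown alone.

Three compounds share one core and differ only in the group attached to the carbonyl carbon. In a functional assay on the whole organism (Tail, strain ICR) with Mus musculus as the target, in the tail flick test, with a stated time of 30 min, at a dose of 25 umol/kg by the oral route (on this read-out higher numbers stand for a stronger effect at the one dose given and lower numbers for a weaker effect), compound 1 `O=C(O)[C@@H]1CCCN1C(=O)CN(c1nc(Cl)nc2[nH]cnc12)C1CC1` gives 31.5%, compound 2 `NC(=O)C[C@H](NC(=O)CN(c1nc(Cl)nc2[nH]cnc12)C1CC1)C(=O)O` gives 29.7%, and compound 3 `C[C@@H](O)[C@H](NC(=O)CN(c1nc(Cl)nc2[nH]cnc12)C1CC1)C(=O)O` gives 18.6%, the lowest of the three. Both measured steps lead down to compound 3: a number 12.9 percentage points lower from compound 1 to compound 3 (beyond the scatter) and a number 11.1 percentage points lower from compound 2 to compound 3 (beyond the scatter). Compound 4 `CC(C)C[C@H](NC(=O)CN(c1nc(Cl)nc2[nH]cnc12)C1CC1)C(=O)O` differs from compound 3 by isobutyl in place of 1-hydroxyethyl on a saturated chain carbon bound to an amide-type nitrogen and a carbonyl carbon. Going by the values given here, no measured step replaces the side chain with a plain hydrocarbon chain, so the earlier steps show only that changes at this carbon move the read-out by modest amounts. The expected step is a number 7.4 percentage points higher from compound 3 to compound 4 (within the scatter), a rise back towards the other two compounds. Compound 4 is estimated at 26%, between 12% and 40%.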

Compound 4, a percentage reported as activity, at one dose (the size of the read-out at that dose, not a potency): 23.4%
Compound 4: the middle estimate sits 2.6 percentage points above what was measured; the measured number falls inside the stated range.
By their numbers in this assay, from the lowest: compounds 3, 4, 2 and 1 (each within the scatter of the next, the first and the last beyond it).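

Isobutyl carries no hydrogen-bond donor or acceptor, unlike the 1-hydroxyethyl it replaces, yet that exchange gives a number 4.8 percentage points higher from compound 3 to compound 4 (within the scatter) and so does not clearly separate the two compounds. Set against the side chain ending in carbamoyl, the hydrocarbon chain gives a number 6.3 percentage points lower from compound 2 to compound 4 (within the scatter), so at this carbon a side chain without a hydrogen-bond donor or acceptor matches both neighbours within the scatter. No measurement here explains these small differences. Still open, from the compounds shown here alone, is what an amine or a longer chain at this carbon would do to the read-out.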